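From 2,4-dichlorobenzyl to 2-fluorobenzyl: an expected cytotoxicity shift

This account rests on a few compounds, and the source may have more. Where it says the series, first, only, none or still open, it means among the compounds named here.

- Compound 1 `Cc1ccccc1Cn1cc(COc2ccc3c(=O)ccoc3c2)nn1` with 15300 nM
- Compound 2 `O=c1ccoc2cc(OCc3cn(Cc4ccc(Cl)cc4Cl)nn3)ccc12` with 80600 nM
- Compound 3 `O=c1ccoc2cc(OCc3cn(Cc4cccc(Cl)c4)nn3)ccc12` with > 100000 nM (a limit, not a number)

In a functional assay on HeLa cells (Homo sapiens) for cytotoxicity, read by MTT assay, with a stated time of 48 h (a higher number here means a weaker inhibitor, a lower number a stronger inhibitor), the series shows a 5.3-fold higher number from compound 1 to compound 2 (0.72 log units; beyond the scatter) which leaves compound 2 with the higher of the two actual numbers. The entry for compound 3 is a limit of the assay. The series also shows an at least 1.2-fold higher number from compound 2 to compound 3 (0.09 log units; that floor lies within the scatter) and so compound 2 cannot be ordered against compound 3.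

The step followed here leads to the unmeasured compound 4 `O=c1ccoc2cc(OCc3cn(Cc4ccccc4F)nn3)ccc12` with 2-fluorophenyl in place of 2,4-dichlorophenyl on a saturated chain carbon bound to an aromatic nitrogen. Among the measured groups, 2-fluorophenyl reads closest to the 2-methylphenyl of compound 1, so a modest move back toward the lower number of compound 1 is expected. The series also shows an at least 6.5-fold higher number from compound 1 to compound 3 (0.81 log units; beyond the scatter) and this warns that other groups may not share the lower number. The expected change is a 2.3-fold lower number from compound 2 to compound 4 (0.36 log units; beyond the scatter) and it remains uncertain. For compound 4 the estimated value is 35000 nM with an expected range from 10000 nM to 100000 nM as the likely span.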

Compound 4, half-maximal inhibitory concentration: > 100000 nM
Compound 4: only a limit was reported; the forecaster's own chance of this, stated with the estimate: 20%; middle value at least 2.8-fold (0.45 log units) away from the limit.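

In this assay compound 4 gives > 100000 nM, which is a limit and not a number. Compound 4 differs from compound 1 by a single swap, fluoro in place of methyl on an aromatic carbon, and that swap gives an at least 6.5-fold higher number from compound 1 to compound 4 (0.81 log units; beyond the scatter), so the lower number of compound 1 does not survive this one change, even with no chlorine present. By contrast, the replacement of 2,4-dichlorophenyl by 2-fluorophenyl gives only an at least 1.2-fold higher number from compound 2 to compound 4 (0.09 log units; that floor lies within the scatter), the step between compound 3 and compound 4 cannot be read, and compound 2, compound 3 and compound 4 cannot be put in order because of the ceiling of the read-out: the limit of > 100000 nM in this assay, at which 2 of the 4 values shown sit.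

As far as these compounds go, it remains open whether the lower number of compound 1 depends on the methyl itself or would also appear with an ethyl or a methoxy group in place of that methyl. The compounds shown also leave open how an unsubstituted phenyl on the same saturated chain carbon would read against compound 1.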